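This account rests on a few compounds, and the source may have more. Where it says the series, first, only, none or still open, it means among the compounds named here.

This study concerns an ADME assay on BJ cells (Homo sapiens) for cytotoxicity, read by CellTiter-Glo and resazurin assay, with a stated time of 72 h; a higher number here means that more compound is needed for the effect, a lower number that less compound is needed. Compound 1 has the structure `CC(=O)Nc1cccc(-c2ccc(C(=O)N(Cc3cccc(OCCCCCC(=O)O)c3)C(C)C)cc2)c1`. In this assay compound 1 gives > 26000 nM, which is a limit of the assay and not a number. Compound 2, `CC(C)N(Cc1cccc(OCCCCCC(=O)O)c1)C(=O)c1ccc(-c2cccc(OC(F)(F)F)c2)cc1`, is made from compound 1 by a change in one group. In this assay compound 2 gives > 26000 nM, again a limit rather than a number. Compound 3, `CCOC(=O)CCCCCOc1cccc(CN(C(=O)c2ccc(-c3cccc(NC(C)=O)c3)cc2)C(C)C)c1`, likewise differs from compound 1 in one place. In this assay compound 3 gives > 26000 nM, once more a limit and not a number. The step that the two limits leave unreadable from compound 1 to compound 2 and the step that the two limits leave unreadable from compound 1 to compound 3 therefore cannot be sized. Compound 3 thus stands exactly where the other two stand, at the limit of > 26000 nM in this assay, at which 3 of the 3 values shown sit. The next compound, compound 4, has the structure `CCOC(=O)CCCCCOc1cccc(CN(C(=O)c2ccc(-c3ccc4cc[nH]c4c3)cc2)C(C)C)c1` and differs from compound 3 in one place: 1H-indol-6-yl in place of 3-acetamidophenyl on an aromatic carbon. Going by the values given here, no measured step bears directly on this change, and the two steps that were measured run between limits, so their size is unknown. Among the compounds with values here, because every value so far sits at the limit of > 26000 nM in this assay, at which 3 of the 3 values shown sit, the step that the limit leaves unreadable from compound 3 to compound 4 is expected to leave compound 4 at or near that same limit. Compound 4 is therefore estimated at 30000 nM in this assay, with a likely range from 10000 nM to 100000 nM, and the assay will most probably again report only a limit.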

Compound 4, half-maximal effective concentration: > 26000 nM
Compound 4: only a limit was reported (the forecaster's own chance of this, stated with the estimate: 75%); the middle value does not contradict the limit.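

Compound 3 and compound 4 each give a limit of the assay and not a number, so the step between them cannot be read. It remains open how much of any compound shown is needed for the effect in this assay and whether any change shown alters that amount, since all the values sit together: the limit of > 26000 nM in this assay, at which 4 of the 4 values shown sit.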